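The source may hold more compounds than are shown below. What is called first, only, known or untested is meant among the compounds shown, and "the series" means these compounds.

Measured in a functional assay on B16-F10 cells (Mus musculus) for antiproliferative activity, read by MTT assay, with a stated time of 48 h; a higher number here means a weaker inhibitor, a lower number a stronger inhibitor:
- Compound 1 `CCCCOc1ccc(C(=O)/C=C/c2c(/C=C/c3ccc(OC)cc3)cc(OC)cc2OC)cc1`: 5.3 ug/mL
- Compound 2 `COc1ccc(/C=C/c2cc(OC)cc(OC)c2/C=C/C(=O)c2ccc(F)cc2)cc1`: 5.3 ug/mL
- Compound 3 `COc1ccc(/C=C/c2cc(OC)cc(OC)c2/C=C/C(=O)c2ccccc2)cc1`: 3.7 ug/mL

Compound 3, at 3.7 ug/mL, lies within the scatter of both other compounds, so the three values in this assay do not separate from one another. Compound 4 `COc1ccc(/C=C/c2cc(OC)cc(OC)c2/C=C/C(=O)c2ccc(C)c(C)c2)cc1` differs from compound 3 in one place, with 3,4-dimethylphenyl in place of phenyl on a carbonyl carbon.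

The measured steps that bear on this change all alter a substituent on that same aromatic group. Hydrogen in place of butoxy gives a 1.4-fold lower number from compound 1 to compound 3 (0.16 log units; within the scatter), hydrogen in place of fluoro gives a 1.4-fold lower number from compound 2 to compound 3 (0.16 log units; within the scatter), and fluoro in place of butoxy gives no change at the digits printed from compound 1 to compound 2 (within the scatter). All three lie within the scatter. None of them involves a methyl group, so the data offer no direct reading of this particular change. Given the small size of a 1.4-fold lower number from compound 1 to compound 3 (0.16 log units; within the scatter) and a 1.4-fold lower number from compound 2 to compound 3 (0.16 log units; within the scatter), no step beyond the scatter is expected in this assay, and no direction is favoured. The expected change is a 1.2-fold higher number from compound 3 to compound 4 (0.09 log units; within the scatter), which is an estimate and remains within the scatter. For compound 4 the estimated value is 4.5 ug/mL, with an expected range from 2.4 ug/mL to 8.5 ug/mL.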

Compound 4, half-maximal inhibitory concentration: 1.4 ug/mL
Compound 4: middle estimate off by 3.2-fold (0.51 log units), on the high side, and the stated range ends above it.
By their numbers in this assay, from the lowest: compound 4; then compounds 3, 1 and 2 (each within the scatter of the next).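

In this assay, among these compounds, the aromatic group on the carbonyl carbon had so far given only steps within the scatter, but 3,4-dimethylphenyl in place of phenyl gives a 2.6-fold lower number from compound 3 to compound 4 (0.42 log units; beyond the scatter) and so shows that this position can respond to what it carries. The same group also separates from the two other substituted rings: replacing 4-fluorophenyl gives a 3.8-fold lower number from compound 2 to compound 4 (0.58 log units; beyond the scatter) and replacing 4-butoxyphenyl gives a 3.8-fold lower number from compound 1 to compound 4 (0.58 log units; beyond the scatter), which leaves compound 4 as the only one of the four whose steps to all the others lie beyond the scatter. No measurement is available that explains why this pair of methyl groups stands apart from the hydrogen, fluoro and butoxy substituents.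

The compounds shown leave open whether a single methyl group on this ring would be enough, or whether both are needed for the lower number. They also leave open how larger alkyl groups such as ethyl or isopropyl, or an amine or a carboxylic acid, would read at this position.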